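Chain-extended propargylamine analogue in the shared series

This account rests on a few compounds, and the source may have more. Where it says the series, first, only, none or still open, it means among the compounds named here.

Measured compounds:
- compound 1 `C[C@H](NCc1ccc(OCCCCCN2CCN(c3cccc4c3ccn4Cc3cccc(Cl)c3)CC2)cc1)C(N)=O` gives 43%
- compound 2 `C[C@H](NCc1ccc(OCCCCCCN2CCN(c3cccc4c3ccn4Cc3cccc(Cl)c3)CC2)cc1)C(N)=O` gives 23%
- compound 3 `C#CCN(C)Cc1ccc(OCCCCCN2CCN(c3cccc4c3ccn4Cc3cccc(Cl)c3)CC2)cc1` gives 100%

All three numbers come from an assay on BTI cells for inhibition of Amine oxidase [flavin-containing] B (Homo sapiens), read by fluorescence, with stated times of 30 min and 1 h, tested at 1 uM; a lower number here means less inhibition, a higher number more inhibition at the concentration tested (going by the name of the read-out). Compound 1 and compound 2 share the same amino group but differ in their cores; that difference between the two cores is not broken down here. Within the data shown here, the one counted change runs from compound 1 to compound 3 methyl(propargyl)amino in place of (1-carbamoylethyl)amino on a saturated chain carbon bound to an aromatic carbon and made the step of a number 57 percentage points higher from compound 1 to compound 3 (beyond the scatter).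

Compound 4 `C#CCN(C)Cc1ccc(OCCCCCCN2CCN(c3cccc4c3ccn4Cc3cccc(Cl)c3)CC2)cc1` is not yet measured. It carries the same change relative to compound 2 (methyl(propargyl)amino in place of (1-carbamoylethyl)amino on a saturated chain carbon bound to an aromatic carbon). Because the step from compound 1 to compound 3 was a number 57 percentage points higher from compound 1 to compound 3 (beyond the scatter), a step of comparable size is expected from compound 2 to compound 4, roughly a number 72 percentage points higher from compound 2 to compound 4 (beyond the scatter) in this assay, starting from the lower number of compound 2. Compound 4 is therefore estimated at 95%, likely between 80% and 100%.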

Compound 4, a percentage reported as inhibition, at one concentration (the size of the read-out at that concentration, not a potency): 32%
For compound 4 the middle estimate is 63 percentage points above the measured one, and the stated range ends above it.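

In this assay, putting methyl(propargyl)amino in place of (1-carbamoylethyl)amino gives a number 9 percentage points higher from compound 2 to compound 4 (within the scatter) and does not repeat the large step seen on the core of compound 1. Among these compounds, with only two pairs, this does not show which feature of the cores sets the outcome, or how the change would behave on any further core. The size of this change therefore does not carry from one core to the other in this series: the same change on two cores in this assay, a number 57 percentage points higher (beyond the scatter) from compound 1 to compound 3 and a number 9 percentage points higher (within the scatter) from compound 2 to compound 4, 48 percentage points apart, beyond the scatter of two such steps

Open, as far as these compounds go, is whether a longer chain in the core would give a large step or a small one. Also open, from the compounds shown here alone, is whether a plain propargylamino group would follow methyl(propargyl)amino on either core.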